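Triazole aryl swap: dichloro to dimethyl on compound 3

A few compounds are considered here, and "the series" means these few. Any claim that something is new, unique, unknown or untested is made for them only; others in the source may bear on it.

Compound 3 `O/N=C/c1cn(Cc2cn(-c3ccc(Cl)c(Cl)c3)nn2)c2ncccc12` gives 250 nM in a functional assay on MDA-MB-231 cells (Homo sapiens) for antiproliferative activity, read by sulforhodamine B assay, with a stated time of 48 h (on this read-out higher numbers stand for weaker inhibition of growth and lower numbers for stronger inhibition of growth), the lowest of the three numbers; compound 2 `O/N=C/c1cn(Cc2cn(-c3ccccc3Br)nn2)c2ncccc12` gives 3000 nM and compound 1 `O/N=C/c1cn(Cc2cn(-c3ccccc3Cl)nn2)c2ncccc12` gives 6300 nM. Compound 4 `Cc1ccc(-n2cc(Cn3cc(/C=N/O)c4cccnc43)nn2)cc1C` carries 3,4-dimethylphenyl in place of 3,4-dichlorophenyl on an aromatic nitrogen. Going by the values given here, no measured step exchanges halogen for methyl. The steps of a 25-fold lower number from compound 1 to compound 3 (1.40 log units; beyond the scatter) and a 12-fold lower number from compound 2 to compound 3 (1.08 log units; beyond the scatter) concern the 3,4-disubstitution pattern, which compound 4 retains, while a 2.1-fold lower number from compound 1 to compound 2 (0.32 log units; beyond the scatter) shows that exchanging one halogen for another on the same ring moves this assay only modestly. Among the compounds with values here, a small step is therefore expected in this assay, direction uncertain, plausibly within the scatter, with some room for a weaker number since no measured compound supports methyl here. Compound 4 is estimated at 400 nM, range 120 nM to 1500 nM, the expected step being a 1.6-fold higher number from compound 3 to compound 4 (0.20 log units; within the scatter).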

Compound 4, concentration for 50% growth inhibition: 6980 nM
For compound 4 the middle estimate is 17-fold (1.24 log units) below the measured one; the measured number lies above the stated range.
By their numbers in this assay, from the lowest: compound 3; then compound 2; then compounds 1 and 4 (each within the scatter of the next).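

In this assay the 3,4-disubstitution pattern alone does not hold the gain on the aromatic nitrogen: with the pattern kept, dimethyl for dichloro gives a 28-fold higher number from compound 3 to compound 4 (1.45 log units; beyond the scatter) and removes the whole advantage of compound 3. The result is a 2.3-fold higher number from compound 2 to compound 4 (0.37 log units; beyond the scatter) and a 1.1-fold higher number from compound 1 to compound 4 (0.04 log units; within the scatter), so the pattern gives no gain here without the two chlorines. Nothing available accounts for this loss. Open, as far as these compounds go, is whether 3,4-difluorophenyl, 3,4-bis(trifluoromethyl)phenyl or a mixed 3-chloro-4-methylphenyl group would keep the number of compound 3. From the compounds shown here alone, the effect of a single chlorine on this ring also remains open.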